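Benzimidazole series against TRPV1: tert-butyl replaced by fluoro

The source may hold more compounds than are shown below. What is called first, only, known or untested is meant among the compounds shown, and "the series" means these compounds.

Of the compounds shown here, two carry the measured numbers so far. Compound 1 `O=C(Nc1ccc(-c2ncccc2C(F)(F)F)cc1)c1ccccc1` is the simpler amide; in a functional assay on CHO cells for antagonist activity at transient receptor potential cation channel subfamily V member 1 (Homo sapiens), read by FLIPR (a lower number here means a stronger inhibitor, a higher number a weaker inhibitor), compound 1 gives 2400 nM. Compound 2 `CC(C)(C)c1ccc(-c2nc3cc(-c4ncccc4C(F)(F)F)ccc3[nH]2)cc1` moves the same trifluoromethyl-pyridyl arm onto a fused core capped by a tert-butyl-bearing aryl ring; in this assay compound 2 gives 224 nM. Among the compounds with values here, compound 2 thus stands at the lower of the two numbers, with compound 1 the only neighbour and its value well beyond the scatter of the gap.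

Compound 3 `Fc1ccc(-c2nc3cc(-c4ncccc4C(F)(F)F)ccc3[nH]2)cc1` keeps the whole of compound 2 except one group: fluoro in place of tert-butyl on an aromatic carbon. Within the data shown here, no measured pair shows this exact swap, so the size of the step can only be judged from how far the series has stretched between compound 1 and compound 2.

The expectation is a weaker inhibitor: the change from compound 2 to compound 3 is estimated at a 6.7-fold higher number from compound 2 to compound 3 (0.83 log units; beyond the scatter), a step beyond the usual scatter but not reaching the spread between compound 1 and compound 2. Compound 3 is therefore estimated at 1500 nM, within a range of 350 nM to 7000 nM.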

Compound 3, half-maximal inhibitory concentration: 320 nM
The estimate for compound 3 lay 4.7-fold (0.67 log units) above the measured number; measured number below the stated range.
By their numbers in this assay, from the lowest: compounds 2 and 3 (each within the scatter of the next); then compound 1.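

In this assay, the aromatic carbon para to a large group takes fluoro in place of tert-butyl with a step of a 1.4-fold higher number from compound 2 to compound 3 (0.15 log units; within the scatter), so compound 2 and compound 3 cannot be told apart at this position. The group leaving has 4 heavy atoms and the group entering has 1 heavy atom, yet this difference in size does not separate the two compounds here, which the earlier pair, differing in more than one place, could not show. Nothing at hand bears on why the two compounds read alike.

Both groups seen at this carbon have 0 hydrogen-bond donors, 0 hydrogen-bond acceptors and no net charge, so the compounds shown leave open how an amine or a carboxylic acid in the same place would read in this assay. Also open, from the compounds shown here alone, is whether compound 2 and compound 3 would still read alike with the trifluoromethyl group of their shared arm replaced by a nitrile.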